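Same atoms, different arrangement: compound 1 and compound 4

The source may report more compounds than this note shows. Statements on the series, on what has been measured and on what is new or still open speak of the compounds shown alone.

Measured in a functional assay on the whole organism (stomach) with Rattus norvegicus as the target; a lower number here means that less compound is needed, a higher number that more compound is needed for the effect:
- compound 1 `C/N=C(\S)CCn1nc(-c2ccccc2)ccc1=O`: 58.5 mg/kg
- compound 2 `C/N=C(\S)CCn1ncccc1=O`: > 100 mg/kg, which is a limit of the assay, not a number
- compound 3 `C/N=C(/S)CCCCCn1nc(-c2ccccc2)ccc1=O`: 25.2 mg/kg

Compound 1 stands highest of the two numbers; its nearest neighbour is compound 3, reached by a 2.3-fold lower number from compound 1 to compound 3 (0.37 log units; beyond the scatter), the longer side chain giving the lower number. The step of an at least 1.7-fold higher number from compound 1 to compound 2 (0.23 log units; that floor lies within the scatter) rests on the limit of > 100 mg/kg in this assay, at which 1 of the 3 values shown sits, and cannot be sized further.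

Compound 4 `CC(Cn1nc(-c2ccccc2)ccc1=O)C(=N)S` keeps every atom of compound 1 and rejoins them: a group of 5 heavy atoms (3 carbon, 1 nitrogen, 1 sulfur; no ring) in place of a group of 5 heavy atoms (3 carbon, 1 nitrogen, 1 sulfur; no ring), on a saturated chain carbon bound to an aromatic nitrogen. Neither measured step is a rearrangement of this kind. Among the measured compounds shown here, the only change in the side chain, from compound 1 to compound 3, was modest, and the change at the aromatic carbon is bounded by a limit. With no step of the same kind shown, a step no larger than the scatter, in either direction, is expected for a 1.0-fold higher number from compound 1 to compound 4 (0.01 log units; within the scatter).

Compound 4 is therefore estimated at 60 mg/kg in this assay, expected within 25 mg/kg to 140 mg/kg.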

Compound 4, dose for half-maximal effect: 28.1 mg/kg
Estimate against measurement, compound 4: 2.1-fold (0.33 log units) above; low and high end bracket the measured number.
By their numbers in this assay, from the lowest: compounds 3 and 4 (each within the scatter of the next); then compound 1. At a limit, above all of these: compound 2.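

In this assay, rejoining the same side-chain atoms is not a neutral change: the record shows a 2.1-fold lower number from compound 1 to compound 4 (0.32 log units; beyond the scatter), so the outcome at this place, on a saturated chain carbon bound to an aromatic nitrogen, depends on how the atoms are joined and not only on which atoms are present. Compound 3 at 25.2 mg/kg and compound 4 at 28.1 mg/kg lie within the scatter of each other, although the entering group in compound 4 has the same heavy-atom count as the group it replaces and 2 hydrogen-bond donors against 1. Nothing measured here accounts for the step.

From the compounds shown here alone, whether the lower number persists with a longer chain in the rearranged group remains open. So does the effect of an amine or a carboxylic acid at this place.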